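The source may hold more compounds than are shown below. What is called first, only, known or untested is meant among the compounds shown, and "the series" means these compounds.

Measured so far:
compound 1 `O=C(CCc1nc2ccccc2c(=O)[nH]1)N/N=C/c1ccc([N+](=O)[O-])cc1`, 328000000 nM in a physicochemical assay, read by spectrophotometry, with a stated time of 30 min; on this read-out lower numbers stand for stronger inhibition and higher numbers for weaker inhibition
compound 2 `COc1ccc(/C=N/NC(=O)CCCc2nc3ccccc3c(=O)[nH]2)cc1`, 247000000 nM in this assay

Compound 2 has the lower of the two numbers, and compound 1 is within the scatter of it, so no order between them can be claimed. Compound 3 `O=C(CCCc1nc2ccccc2c(=O)[nH]1)N/N=C/c1cc(O)c(O)c(O)c1` is not yet measured. Its change from compound 2: 3,4,5-trihydroxyphenyl in place of 4-methoxyphenyl on a carbon with a double bond to nitrogen. Going by the values given here, no step between measured compounds is known, so the size of this change is uncertain; a drop in the number beyond the scatter is expected in this assay, though the two measured values give no direct ground for its size. For compound 3 the expected value is 60000000 nM, with a range from 5000000 nM to 300000000 nM, an expected step of a 4.1-fold lower number from compound 2 to compound 3 (0.61 log units; beyond the scatter).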

Compound 3, half-maximal inhibitory concentration: 78000000 nM
Estimate against measurement, compound 3: 1.3-fold (0.11 log units) below; the measured number falls inside the stated range.
By their numbers in this assay, from the lowest: compound 3; then compounds 2 and 1 (each within the scatter of the next).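

With the group on the carbon with a double bond to nitrogen as the only difference, 3,4,5-trihydroxyphenyl in place of 4-methoxyphenyl gives a step beyond the scatter in this assay (a 3.2-fold lower number from compound 2 to compound 3 (0.50 log units; beyond the scatter)). This position therefore responds to a change of group, which the two earlier compounds could not show. No measurement available here explains the step.

Going by these compounds, whether the step needs all three hydroxyl groups or follows from the loss of the methoxy group remains open. The same position carrying 4-hydroxyphenyl, 3,4-dihydroxyphenyl or an aminophenyl group would separate these readings.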